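The compounds below may be only part of what the source reports. "The series", "measured", "known", "first", "only" and "open" are said of these compounds alone.

Compound 1 `COc1cc(-c2nn(-c3cccc(NC(=O)Nc4cc(C(F)(F)F)cc(C(F)(F)F)c4)c3)cc2-c2ccncc2)ccc1Cl` — in a functional assay on MOLT-4 cells (Homo sapiens) for inhibition, read by sulforhodamine B assay, with a stated time of 48 h (a lower number here means that less compound is tolerated, a higher number that more compound is tolerated), compound 1 gives > 50000 nM, which is a limit of the assay rather than a number.
Compound 2 `O=C(Nc1cccc(-n2cc(-c3ccncc3)c(-c3ccc(Cl)c(O)c3)n2)c1)Nc1cc(C(F)(F)F)cc(C(F)(F)F)c1` — in this assay compound 2 gives > 50000 nM, again a limit and not a number.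
Compound 3 `COc1cc(-c2nn(-c3cccc(NC(=O)Nc4ccc(Cl)c(C(F)(F)F)c4)c3)cc2-c2ccncc2)ccc1Cl` — in this assay compound 3 gives > 32500 nM, also a limit and not a number.

Compound 4 `O=C(Nc1cccc(-n2cc(-c3ccncc3)c(-c3ccc(Cl)c(O)c3)n2)c1)Nc1ccc(Cl)c(C(F)(F)F)c1` has not yet been measured. It is related to compound 3 by one change, (hydrogen in place of methyl on an oxygen on an aromatic ring). The same change is found between compound 1 and compound 2, (hydrogen in place of methyl on an oxygen on an aromatic ring), and the place of the change is the same in both pairs. The measured step for that change, a step that the two limits leave unreadable from compound 1 to compound 2, cannot be read in size, since both of its end points are limits. The cores of compound 1 and compound 3 differ in more than one place, and that difference is not broken down here.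

All three values sit at limits: the limit of > 50000 nM in this assay, at which 2 of the 3 values shown sit, and (the limit of > 32500 nM in this assay, at which 1 of the 3 values shown sits). Going by the values given here, none of the measured compounds reaches a readable concentration in this assay, so no numerical step is available to carry over. Compound 4 is therefore expected to behave like its neighbours, and its value is estimated at 50000 nM, with a range from 30000 nM to 100000 nM, most likely reported again as a limit. The step this implies, a step that the limit leaves unreadable from compound 3 to compound 4, is expected to be essentially flat, because compound 3 stands at > 32500 nM and compound 2, carrying the same change, stands at > 50000 nM.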

Compound 4, concentration lethal to 50% of the cells: > 32500 nM
Compound 4: only a limit was reported; the forecaster's own chance of this, stated with the estimate: 85%; the middle value lies beyond the limit too.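

In this assay compound 4 gives > 32500 nM, which is a limit of the assay and not a number. Compound 3 gives > 32500 nM, likewise a limit, so the step between compound 3 and compound 4 cannot be read. All four compounds shown stand at limits, and they leave open what size, if any, the change from methoxy to hydroxy has in this assay.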